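The source may hold more compounds than are shown below. What is called first, only, known or untested is meant among the compounds shown, and "the series" means these compounds.

Measured so far:
compound 1 `Cc1nn(-c2ncnc3nc[nH]c23)c2c1C(OCc1ccc(C(C)C)cc1)CC(=O)N2` — 5 nM
compound 2 `C=CCN1c2c(n(C)c(=O)n(C)c2=O)NC1N/N=C/c1ccc(O)cc1O` — 340 nM

Compound 1 gives the lower of the two numbers recorded in a functional assay on HEK293 cells for agonist activity at G-protein coupled receptor 39 (Homo sapiens), read by scintillation proximity assay and inositol phosphate accumulation, with a stated time of 75 min, in the presence of a further agent that is not named here; on this read-out higher numbers stand for an effect only at larger amounts of compound and lower numbers for an effect already at smaller amounts; compound 2 sits at a markedly higher number, and the gap between the two values is beyond the scatter of repeated measurements. For the measured compounds named here, no step between two measured compounds that differ in one place is available, so what follows rests on compound 1 alone and on the nature of the change.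

Compound 3 `Cc1nn(-c2ncnc3nc[nH]c23)c2c1C(OC(=O)c1ccc(F)cc1)CC(=O)N2` has not yet been measured in this assay. It is derived from compound 1 by the change ((4-fluorophenyl)carbonyl in place of 4-isopropylbenzyl on an oxygen on a saturated carbon). The ether oxygen of compound 1 is kept, but the group it carries is replaced by a carbonyl-linked aromatic ring bearing fluorine, turning the ether into an ester.

Going by the values given here, with no measured pair to lean on, the account expects a modest step from compound 1 to compound 3 towards higher numbers, of size a 4.0-fold higher number from compound 1 to compound 3 (0.60 log units; beyond the scatter). Compound 3 is therefore estimated at 20 nM, with a range from 4 nM to 150 nM.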

Compound 3, half-maximal effective concentration: 4 nM
The estimate for compound 3 lay 5.0-fold (0.70 log units) above the measured number; low and high end bracket the measured number.
By their numbers in this assay, from the lowest: compounds 3 and 1 (each within the scatter of the next); then compound 2.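

Exchanging 4-isopropylbenzyl for (4-fluorophenyl)carbonyl on an oxygen on a saturated carbon gives, in this assay, a 1.3-fold lower number from compound 1 to compound 3 (0.10 log units; within the scatter), which turns the ether of compound 1 into the ester of compound 3. Compound 1 alone could not show whether this group could be exchanged; the pair now shows that a benzyl ether and an aroyl ester on this oxygen give values that cannot be told apart, even though the entering group brings a carbonyl, a fluorine and a hydrogen-bond acceptor while keeping one six-membered aromatic ring. No measurement is at hand that would account for this result.

On these data alone, compound 1 and compound 3 differ in the linking carbonyl, the isopropyl group and the fluorine all at once, so the contribution of each to the values remains open. As far as these compounds go, it also remains open whether a much smaller group such as methyl, a free hydroxyl or an amine at this place, or a longer chain between the oxygen and the aromatic ring, would stay in the same range.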